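Series notes: methylphenyl variant of compound 2

The compounds below may be only part of what the source reports. "The series", "measured", "known", "first", "only" and "open" are said of these compounds alone.

Compound 2 `Clc1ccc(-n2cc(CSc3nc4ccccc4s3)nn2)cc1` in a functional assay on the whole organism (strain Albino Wistar) for inhibition, with Rattus norvegicus as the target, read by paw edema, with stated times of 1 h and 3 h, at a dose of 10 mg/kg by the oral route (a lower number here means less inhibition, a higher number more inhibition at the dose given (going by the name of the read-out)), gives 50%, the second highest of the three measured numbers. Compound 1 `Clc1cccc(-n2cc(CSc3nc4ccccc4s3)nn2)c1` gives 35%, and the step of a number 15 percentage points higher from compound 1 to compound 2 (beyond the scatter) lies beyond the scatter. Compound 3 `O=[N+]([O-])c1ccc(-n2cc(CSc3nc4ccccc4s3)nn2)cc1` gives 75%; the step of a number 25 percentage points higher from compound 2 to compound 3 (beyond the scatter) also lies beyond the scatter. Compound 4 `Cc1ccccc1-n1cc(CSc2nc3ccccc3s2)nn1` differs from compound 2 by 2-methylphenyl in place of 4-chlorophenyl on an aromatic nitrogen, the new group entering on the aromatic nitrogen next to the ring nitrogen. Neither measured step bears directly on this change, since no methyl occurs among the measured compounds; only a number 15 percentage points higher from compound 1 to compound 2 (beyond the scatter) touches on a shift of the group about the phenyl, and there the 3-chlorophenyl of compound 1 gave the lower number. A decrease beyond the scatter is therefore expected, a number 15 percentage points lower from compound 2 to compound 4 (beyond the scatter). Compound 4 is estimated at 35%, within 20% to 50%.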

Compound 4, a percentage reported as inhibition, in the whole organism at one dose (the size of the read-out at that dose, not a potency): 47.3%
Compound 4: the middle estimate sits 12.3 percentage points below what was measured, within the range that was stated.
By their numbers in this assay, from the lowest: compound 1; then compounds 4 and 2 (each within the scatter of the next); then compound 3.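

In this assay the swap of 4-chlorophenyl for 2-methylphenyl on the aromatic nitrogen gives a number 2.7 percentage points lower from compound 2 to compound 4 (within the scatter) and so costs nothing that can be told from the scatter, which shows that this position accepts a phenyl without chlorine. The swap of 3-chlorophenyl for the same group gives a number 12.3 percentage points higher from compound 1 to compound 4 (beyond the scatter) in the same read-out, so the low number of compound 1 does not extend to every substituted phenyl here. Nothing available explains these readings.

On these data alone, it stays open whether the number of compound 4 follows from the methyl itself or from where it sits. As far as these compounds go, how 4-methylphenyl or an aminophenyl would read at this position is also open.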